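Notes on the shared core: one substituent swap toward compound 3

A few compounds are considered here, and "the series" means these few. Any claim that something is new, unique, unknown or untested is made for them only; others in the source may bear on it.

Two compounds on the shared core have been run through an in vitro ADME assay on microsomes from liver (Mus musculus) for metabolic stability; a lower number here means slower removal, a higher number faster removal of the compound. Compound 1 `Cc1cc(Nc2ccc(C(F)(F)F)cc2)n2nc(CCO)nc2n1` gives 6.9 mL.min-1.g-1 in this assay. Compound 2 `Cc1cc(Nc2ccc(S(F)(F)(F)(F)F)cc2)n2nc(C3CC3)nc2n1` gives 12.6 mL.min-1.g-1 in this assay, the highest of the two numbers; its nearest neighbour is compound 1, and the gap between them lies within the usual scatter of this measurement, so no order between the two is claimed. Compound 3 `Cc1cc(Nc2ccc(C(F)(F)F)cc2)n2nc(C3CC3)nc2n1` has not yet been measured in this assay. It is reached from compound 2 by a single change: a group of 4 heavy atoms (1 carbon, 3 fluorine; no ring) in place of a group of 6 heavy atoms (5 fluorine, 1 sulfur; no ring), on an aromatic carbon. Going by the values given here, no step between measured compounds that differ in one place is available, and compounds 1 and 2 differ in two places, so the effect of this change alone cannot be read off. Compound 3 does carry the trifluoromethyl group present in compound 1. The step of a 1.3-fold lower number from compound 2 to compound 3 (0.10 log units; within the scatter) is expected to be small, downward if anything, and not beyond the scatter. Compound 3 is therefore estimated at 10 mL.min-1.g-1 in this assay, with a range from 5 mL.min-1.g-1 to 20 mL.min-1.g-1.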

Compound 3, intrinsic clearance in microsomes: 8.6 mL.min-1.g-1
The estimate for compound 3 lay 1.2-fold (0.07 log units) above the measured number; low and high end bracket the measured number.
By their numbers in this assay, from the lowest: compounds 1, 3 and 2 (each within the scatter of the next).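

In this assay, trifluoromethyl in place of the group of 6 heavy atoms (5 fluorine, 1 sulfur), on an aromatic carbon para to a large group, gives a 1.5-fold lower number from compound 2 to compound 3 (0.17 log units; within the scatter) and so shows no effect of this swap that can be told from the scatter. The second place in which compounds 1 and 2 differ can now also be read alone: cyclopropyl in place of 2-hydroxyethyl on an aromatic carbon gives a 1.2-fold higher number from compound 1 to compound 3 (0.10 log units; within the scatter) and likewise shows no effect beyond the scatter. No supporting data bear on either step.

Both steps rest on single pairs, so neither can be generalised to other compounds on the shared core. On these data alone, whether a nitrile at the first place, or an amine or a carboxylic acid in place of cyclopropyl, would give a step beyond the scatter remains open.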